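Core substituent swap at compound 2: expectation for compound 4

A few compounds are considered here, and "the series" means these few. Any claim that something is new, unique, unknown or untested is made for them only; others in the source may bear on it.

The series shares a core carrying an aryl ether on the fused ring and an amine-linked chain ending in a benzyl-type group. Compound 2 `COc1ccc(Oc2ccc3c(NCCCNCc4cccc(OC)c4O)ccnc3c2)cc1` gives 5500 nM in an ADME assay on HepG2 cells (Homo sapiens) for cytotoxicity, read by luminescence, CellTiter-Glo and ATP content, with a stated time of 72 h; a lower number here means that less compound is needed, a higher number that more compound is needed for the effect. Compound 1 `COc1ccc(Oc2ccc3c(NCCCNCc4cc(F)ccc4OC)ccnc3c2)cc1` gives 7000 nM in this assay, and the step of a 1.3-fold lower number from compound 1 to compound 2 (0.10 log units; within the scatter) changes only the group on the saturated chain carbon bound to an amine nitrogen. Going by the values given here, compound 3 `CC(C)(C)c1ccc(Oc2ccc3c(NCCCNCc4ccco4)ccnc3c2)cc1` gives 3100 nM in this assay; it differs from compound 2 at both ends, so no single step is drawn between them. Compound 2 therefore sits in a narrow cluster with the other two numbers.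

Compound 4 `COc1cccc(CNCCCNc2ccnc3cc(-c4ccccc4)ccc23)c1O` is not yet measured. The change from compound 2 is phenyl in place of 4-methoxyphenoxy on an aromatic carbon, so the group leaving is the 4-methoxyphenoxy and the group entering is a phenyl, at the position meta to a fused ring and para to a fused ring. Among the compounds with values here, none of the measured steps touches this position; the one step drawn, from compound 1 to compound 2, concerns the chain end only and stayed within the scatter. No direction is therefore expected beyond the scatter, and the estimated step of a 1.1-fold lower number from compound 2 to compound 4 (0.04 log units; within the scatter) is taken as flat. Compound 4 is expected to give about 5000 nM in this assay, within 1500 nM to 16000 nM.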

Compound 4, half-maximal effective concentration: 3210 nM
The estimate for compound 4 lay 1.6-fold (0.19 log units) above the measured number; the range from low to high includes it.
By their numbers in this assay, from the lowest: compounds 3, 4, 2 and 1 (each within the scatter of the next, the first and the last beyond it).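

In this assay, going by these compounds alone, the step of a 1.7-fold lower number from compound 2 to compound 4 (0.23 log units; within the scatter) is the first reading at this position, an aromatic carbon meta to a fused ring and para to a fused ring, which none of the earlier steps touched. The group leaving, 4-methoxyphenoxy, has 9 heavy atoms and 2 hydrogen-bond acceptors, while the phenyl entering has 6 heavy atoms and 0 hydrogen-bond acceptors, so for this pair the position accepts that exchange without a change beyond the scatter. Nothing measured in the material at hand accounts for this result.

The position is read through this single exchange of one aromatic ring for another, so a group of a different kind here, such as a primary amine, a carboxylic acid or a morpholine ring, remains an open case in this cytotoxicity read-out. The exchange is also seen with only one chain end, 2-hydroxy-3-methoxyphenyl, and whether phenyl in place of 4-methoxyphenoxy gives a similar step alongside 5-fluoro-2-methoxyphenyl stays unsettled.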